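Fluorophenyl ketone series: moving the ring fluorine

A few compounds are considered here, and "the series" means these few. Any claim that something is new, unique, unknown or untested is made for them only; others in the source may bear on it.

Measured so far:
compound 1 `COc1cc(OC)c(C(=O)c2ccccc2F)c(O)c1CN1CCCC1`: 87%
compound 2 `COc1cc(O)c(C(=O)c2ccccc2F)c(OC)c1`: 71%

In a functional assay on THP-1 cells (Homo sapiens) for inhibition, read by ELISA, with stated times of 30 min and 24 h, tested at 10 uM (on this read-out higher numbers stand for a stronger effect at the one concentration tested and lower numbers for a weaker effect), compound 1 gives the higher of the two numbers. Among the compounds with values here, the only measured step, a number 16 percentage points lower from compound 1 to compound 2 (beyond the scatter), concerns the (pyrrolidin-1-yl)methyl group and not the fluorophenyl ring. Compound 3 `COc1cc(OC)c(C(=O)c2cccc(F)c2)c(O)c1CN1CCCC1` differs from compound 1 as follows: 3-fluorophenyl in place of 2-fluorophenyl on a carbonyl carbon. No measured step touches the fluorophenyl group, so nothing shown bears on this change, and no step beyond the scatter is expected: a number 7 percentage points lower from compound 1 to compound 3 (within the scatter). Compound 3 is therefore estimated at 80%, expected between 60% and 95%.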

Compound 3, a percentage reported as activity, at one concentration (the size of the read-out at that concentration, not a potency): 93%
Compound 3: middle estimate off by 13 percentage points, on the low side; the measured number falls inside the stated range.
By their numbers in this assay, from the lowest: compound 2; then compounds 1 and 3 (each within the scatter of the next).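

In this assay the change from 2-fluorophenyl to 3-fluorophenyl on a carbonyl carbon gives a number 6 percentage points higher from compound 1 to compound 3 (within the scatter) and is the only step shown on the fluorophenyl group. With the (pyrrolidin-1-yl)methyl group kept, the two fluorine placements cannot be told apart at the one concentration tested. Nothing available accounts for this result.

Still open, on these data alone, is whether a chlorine or methoxy group in place of the fluorine, or an unsubstituted phenyl, would hold the read-out. Any difference in potency between compound 1 and compound 3 also remains unresolved.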